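Dimethylamino in place of pyrrolidin-1-yl on a thiocarbonyl carbon

The source may hold more compounds than are shown below. What is called first, only, known or untested is meant among the compounds shown, and "the series" means these compounds.

Compound 2 `O=C(CC(SC(=S)N1CCCC1)c1ccccc1)c1ccccc1` was tested in a functional assay on the whole organism for inhibition, with Cicer arietinum as the target, with a stated time of 7 days (a higher number here means a weaker inhibitor, a lower number a stronger inhibitor), where compound 2 gave 1670 nM. This is the lower of the two numbers recorded so far, but only marginally: compound 1 `CN(C)C(=S)SCc1nc2ccccc2[nH]1` in this assay gave 2120 nM, a value within the scatter of that of compound 2, so the two cannot be told apart. Compound 3 `CN(C)C(=S)SC(CC(=O)c1ccccc1)c1ccccc1` differs from compound 2 in one place: dimethylamino in place of pyrrolidin-1-yl on a thiocarbonyl carbon. For the measured compounds named here, no measured pair isolates this change, so its size cannot be read from the data. The change is a small one at the thiocarbonyl carbon, and the expected step is a 1.0-fold higher number from compound 2 to compound 3 (0.01 log units; within the scatter), that is, none beyond the usual scatter. Compound 3 is therefore estimated to give 1700 nM in this assay, within a range from 800 nM to 3600 nM.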

Compound 3, half-maximal inhibitory concentration: 2430 nM
Compound 3: middle estimate off by 1.4-fold (0.16 log units), on the low side, and the stated range covers the measured number.
By their numbers in this assay, from the lowest: compounds 2, 1 and 3 (each within the scatter of the next).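

In this assay, for the compounds shown here, the exchange of pyrrolidin-1-yl for dimethylamino on a thiocarbonyl carbon gives a 1.5-fold higher number from compound 2 to compound 3 (0.16 log units; within the scatter) and is the only measured pair that isolates this change. At this position, the five-membered non-aromatic ring can therefore be replaced by the open dimethylamino group without a step that can be told from the usual scatter, so the ring is not shown to matter for the read-out in this pair. No measurement of any property of the two groups bears on this result, and no explanation for it can be offered.

On these data alone, it remains open whether other amines on the thiocarbonyl carbon, such as piperidin-1-yl, morpholin-4-yl or diethylamino, would also stay within the scatter of compound 2. As far as these compounds go, it also remains open whether pyrrolidin-1-yl in place of dimethylamino on the core of compound 1 would behave in the same way.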